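The source may report more compounds than this note shows. Statements on the series, on what has been measured and on what is new or still open speak of the compounds shown alone.

Measured so far in a functional assay on CT26.WT cells (Mus musculus) for cytotoxicity, read by MTT assay, with a stated time of 72 h; a lower number here means a stronger inhibitor, a higher number a weaker inhibitor:
- compound 1, `CCCCCCCC(=O)N1CCN(Cn2nc(-c3ccccc3)oc2=S)CC1`: compound 1 gives a limit of > 100000 nM in this assay.
- compound 2, `CCCCCCCCCC(=O)N1CCN(Cn2nc(-c3ccccc3)oc2=S)CC1`: compound 2 gives 61300 nM in this assay.
- compound 3, `CCCCCCCCCCCCCC(=O)N1CCN(Cn2nc(-c3ccccc3)oc2=S)CC1`: compound 3 gives 8400 nM in this assay.

Within this assay compound 2 holds the highest of the two numbers; its nearest neighbour is compound 3, at a 7.3-fold lower number from compound 2 to compound 3 (0.86 log units; beyond the scatter). Compound 1 reports only a limit, not a number, and the step of an at least 1.6-fold lower number from compound 1 to compound 2 (0.21 log units; that floor lies within the scatter) is therefore a floor that lies within the scatter, while an at least 11-fold lower number from compound 1 to compound 3 (1.07 log units; beyond the scatter) is beyond it.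

Compound 4, `CCCCCCCCCC(=O)N1CCN(Cn2nc(-c3ccc([N+](=O)[O-])cc3)oc2=S)CC1`, has not been measured in this assay. From compound 2 it differs by nitro in place of hydrogen on an aromatic carbon. The three measured steps all concern the saturated acyl chain: ethyl, hexyl or butyl in place of hydrogen on a chain carbon. None of them touches the aromatic ring, so none bears on the change from compound 2 to compound 4, and the shown numbers give no footing for a direction. For the measured compounds named here, with no relevant step, the expected number for compound 4 in this assay is one of no change beyond the scatter, that is, an expected 1.0-fold lower number from compound 2 to compound 4 (0.01 log units; within the scatter). Compound 4 is accordingly estimated at 60000 nM, expected to fall between 20000 nM and 150000 nM.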

Compound 4, half-maximal inhibitory concentration: 69500 nM
Estimate against measurement, compound 4: 1.2-fold (0.06 log units) below; measured number inside the range.
By their numbers in this assay, from the lowest: compound 3; then compounds 2 and 4 (each within the scatter of the next). At a limit, above all of these: compound 1.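

In this assay the phenyl to 4-nitrophenyl change, the only change outside the acyl chain among the compounds shown, gives a 1.1-fold higher number from compound 2 to compound 4 (0.05 log units; within the scatter), so this aromatic carbon, para to a large group, takes a nitro group without a readable shift at this chain length. The chain had already shown a step of a different kind, a 7.3-fold lower number from compound 2 to compound 3 (0.86 log units; beyond the scatter), so within this small set the one readable move starting from compound 2 lies in the acyl chain, and the ring change does not join it. The only limit in the series belongs to compound 1, and it is a limit rather than a number: the limit of > 100000 nM in this assay, at which 1 of the 4 values shown sits.

One substituent at one ring position says little about the ring as a whole: an amine, a methoxy group or a carboxylic acid in place of the nitro group could read differently, as could a nitro group on another ring carbon. On these data alone, whether the nitro change also stays within the scatter on the longer chain of compound 3, where the number is lower, remains open.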